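A few compounds are considered here, and "the series" means these few. Any claim that something is new, unique, unknown or untested is made for them only; others in the source may bear on it.

Measured so far:
- compound 1 `Cc1ccc(C(=O)/C=C/c2cc(Cl)cc(Cl)c2Oc2c([N+](=O)[O-])cc(C(F)(F)F)cc2[N+](=O)[O-])cc1`: 0.7 ug/mL
- compound 2 `Cc1ccc(C(=O)/C=C/c2cccc(Br)c2Oc2c([N+](=O)[O-])cc(C(F)(F)F)cc2[N+](=O)[O-])cc1`: 0.55 ug/mL

In a functional assay on MCF7 cells (Homo sapiens) for antiproliferative activity, read by MTT assay, with a stated time of 48 h (on this read-out lower numbers stand for stronger inhibition and higher numbers for weaker inhibition), compound 1 gives 0.7 ug/mL and compound 2 gives 0.55 ug/mL, so the two numbers lie within the scatter of each other. Compound 3 `Cc1ccc(C(=O)/C=C/c2cccc(Cl)c2Oc2c([N+](=O)[O-])cc(C(F)(F)F)cc2[N+](=O)[O-])cc1` follows from compound 1 by one change: hydrogen in place of chloro on an aromatic carbon. For the measured compounds named here, no measured step isolates this change, so no step beyond the scatter is expected in this assay. The expected step is small: a 1.2-fold lower number from compound 1 to compound 3 (0.07 log units; within the scatter). Compound 3 is estimated at 0.6 ug/mL, with an expected range of 0.25 ug/mL to 1.4 ug/mL.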

Compound 3, half-maximal inhibitory concentration: 0.03 ug/mL
Compound 3: the middle estimate sits 20-fold (1.30 log units) above what was measured, outside the stated range (below it).
By their numbers in this assay, from the lowest: compound 3; then compounds 2 and 1 (each within the scatter of the next).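

In this assay the halogen pattern on this ring is far from silent. Hydrogen in place of the chloro para to a large group and meta to a 2-((4-methylphenyl)carbonyl)ethenyl group gives a 23-fold lower number from compound 1 to compound 3 (1.37 log units; beyond the scatter), and chloro in place of bromo on the other halogen-bearing carbon gives an 18-fold lower number from compound 2 to compound 3 (1.26 log units; beyond the scatter), so both changes produce large steps. Nothing available bears on what lies behind these steps.

The compounds shown leave open whether fluoro, methoxy or an amine on either carbon would keep the low number of compound 3.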